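The compounds below may be only part of what the source reports. "The series", "measured", "known", "first", "only" and "open" are said of these compounds alone.

Measured compounds:
- compound 1 `CC1(C)Cc2c(OCc3ccccc3)ccc(C(=O)/C=C/c3ccc(Br)cc3)c2O1`: > 100000 nM
- compound 2 `CC1(C)Cc2c(ccc(C(=O)/C=C/c3cn(-c4ccccc4)nc3-c3ccc(Cl)cc3)c2OCc2ccccc2)O1`: 26000 nM
- compound 3 `CC1(C)Cc2c(OCc3ccccc3)ccc(C(=O)/C=C/c3cn(-c4ccccc4)nc3-c3cccc([N+](=O)[O-])c3)c2O1`: 5900 nM

All three were tested in a functional assay on PC-3 cells (Homo sapiens) for antiproliferative activity, read by MTT assay, with a stated time of 48 h; a higher number here means a weaker inhibitor, a lower number a stronger inhibitor. Compound 1 carries a 4-bromophenyl group on the ethenyl arm of the shared core. For compound 1 the result is only a limit of the assay: the value > 100000 nM says that no half-maximal inhibition was reached within the tested range, and it sits at the limit of > 100000 nM in this assay, at which 1 of the 3 values shown sits. Compound 2 and compound 3 carry a larger, differently built arm in the same region, and in this assay compound 2 gives 26000 nM, while compound 3 gives 5900 nM. Among the compounds with values here, no single-change step between measured compounds exists here, so nothing is known about how a small change on the bromophenyl ring shifts the number.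

Compound 4 `CC1(C)Cc2c(OCc3ccccc3)ccc(C(=O)/C=C/c3ccc(Cl)cc3)c2O1` is the next compound, not yet measured. Its difference from compound 1 is this: chloro in place of bromo on an aromatic carbon. This is a small exchange of one halogen for another, and compound 1 itself gave only a limit. Compound 4 is therefore expected to stay near that limit, with a step that the limit leaves unreadable from compound 1 to compound 4 that is not expected to exceed the usual scatter. The estimate for compound 4 in this assay is 120000 nM, with a likely range from 40000 nM to 400000 nM, and a high chance that again only a limit is reported.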

Compound 4, half-maximal inhibitory concentration: > 100000 nM
Compound 4 was reported as a limit (the forecaster's own chance of this, stated with the estimate: 70%); the middle value lies beyond the limit too.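

Compound 1 and compound 4 both gave only a limit of the assay, so swapping bromo for chloro yields no step that can be read: the limit of > 100000 nM in this assay, at which 2 of the 4 values shown sit.

The compounds shown leave open whether any other group at that place on the ring would give a measurable value in this assay.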